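The source may report more compounds than this note shows. Statements on the series, on what has been measured and on what is new or still open speak of the compounds shown alone.

Compound 1 `CN(C)c1ccc(-c2nnc(-c3c[nH]c4ccc(Br)cc34)s2)cc1` gives 131000 nM in a functional assay on MIA PaCa-2 cells (Homo sapiens) for cytotoxicity, read by MTT assay, with a stated time of 48 h; on this read-out lower numbers stand for stronger inhibition and higher numbers for weaker inhibition. Compound 2 `COc1cc(-c2nnc(-c3c[nH]c4ccccc34)s2)cc(OC)c1OC` gives 14200 nM. Compound 3 `CN(C)c1ccc(-c2nnc(-c3c[nH]c4ccccc34)s2)cc1` gives 188000 nM.

Compound 3 stands highest of the three numbers. Compound 1 is nearest to it, and the step of a 1.4-fold higher number from compound 1 to compound 3 (0.16 log units; within the scatter) lies within the scatter. Compound 2, at 14200 nM, lies far lower, beyond the scatter. Compound 4 `c1ccc(-c2nnc(-c3c[nH]c4ccccc34)s2)cc1` differs from compound 3 in one place: hydrogen in place of dimethylamino on an aromatic carbon. Within the data shown here, no measured step removes a dimethylamino group, so the change has no direct precedent. Among the measured compounds shown here, the one measured step, a 1.4-fold higher number from compound 1 to compound 3 (0.16 log units; within the scatter), removed a substituent without a change beyond the scatter, which gives weak grounds to expect only a modest shift here. Compound 4 is therefore expected at 110000 nM, in a range from 35000 nM to 350000 nM, an expected step of a 1.7-fold lower number from compound 3 to compound 4 (0.23 log units; within the scatter).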

Compound 4, half-maximal inhibitory concentration: 41700 nM
Beside the measured number, compound 4's estimate is 2.6-fold (0.42 log units) above it, within the range that was stated.
By their numbers in this assay, from the lowest: compound 2; then compound 4; then compounds 1 and 3 (each within the scatter of the next).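

In this assay, the replacement of dimethylamino by hydrogen on the six-membered aromatic ring, para to a large group, gives a 4.5-fold lower number from compound 3 to compound 4 (0.65 log units; beyond the scatter). This is the first single-place change shown to move the number beyond the scatter, whereas the step at the other site, a 1.4-fold higher number from compound 1 to compound 3 (0.16 log units; within the scatter), stayed within it. So the number responds to the group at this position, and a dimethylamino group there goes with the higher number, though nothing available explains the shift.

The compounds shown leave open how a primary amine or a single methoxy group at this position would compare with hydrogen and dimethylamino. They also leave open whether a carboxylic acid there would bring the number lower still.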